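The compounds below may be only part of what the source reports. "The series", "measured", "known", "first", "only" and "open" are said of these compounds alone.

Compound 1, `Nc1nc(Cl)c(-c2nc3ccccc3s2)c(N[C@@H]2C[C@H](CO)[C@@H](O)[C@H]2O)n1`: in an ADME assay on cells (Homo sapiens) for cytotoxicity, read by polymerase chain reaction, with a stated time of 3 days (on this read-out higher numbers stand for lower toxicity in this test and lower numbers for higher toxicity in this test), compound 1 gives 14000 nM.
Compound 2, `CNc1ccc2sc(-c3c(Cl)nc(N)nc3N[C@@H]3C[C@H](CO)[C@@H](O)[C@H]3O)nc2c1`: in this assay compound 2 gives 20000 nM.
Compound 3, `COCCNc1nc(C)c(-c2nc3ccccc3s2)c(N[C@@H]2C[C@H](CO)[C@@H](O)[C@H]2O)n1`: in this assay compound 3 gives 21000 nM.

All three numbers lie close together: compound 3 sits within the scatter of compound 2 and of compound 1, so no order among the three is supported. Among the compounds with values here, the only single-point step measured so far, a 1.4-fold higher number from compound 1 to compound 2 (0.15 log units; within the scatter), changes a substituent on an aromatic carbon and stays within the scatter.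

Compound 4, `Cc1nc(NCc2nccs2)nc(N[C@@H]2C[C@H](CO)[C@@H](O)[C@H]2O)c1-c1nc2ccccc2s1`, is not yet measured in this assay. It differs from compound 3 in one place: 1,3-thiazol-2-yl in place of methoxymethyl on a saturated chain carbon bound to a nitrogen on an aromatic ring. Within the data shown here, no measured step touches this position or this kind of exchange, so the step from compound 1 to compound 2 bears on it only indirectly, as a sign that a single substituent change left the cytotoxicity read-out within the scatter. On that basis no step beyond the scatter is expected, in either direction: the expected step is a 1.1-fold lower number from compound 3 to compound 4 (0.02 log units; within the scatter). Compound 4 is therefore estimated at 20000 nM, with a range from 9000 nM to 45000 nM.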

Compound 4, half-maximal cytotoxic concentration: 23000 nM
Compound 4: the middle estimate sits 1.2-fold (0.06 log units) below what was measured; low and high end bracket the measured number.
By their numbers in this assay, from the lowest: compounds 1, 2, 3 and 4 (each within the scatter of the next).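

At this place, on a saturated chain carbon bound to a nitrogen on an aromatic ring, 1,3-thiazol-2-yl in place of methoxymethyl gives a 1.1-fold higher number from compound 3 to compound 4 (0.04 log units; within the scatter) in this assay, so exchanging an open chain for a five-membered aromatic ring leaves the read-out within the scatter. Within the data shown here, this is the first measured step at this position, as the earlier step concerned a substituent on an aromatic carbon. No measurement at hand accounts for this result.

Going by these compounds, whether an amine, a carboxylic acid or a longer chain at this place would also stay within the scatter of compound 3 remains open. Among these compounds, with only this one step at the position, how far the result extends to other groups also remains open.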